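A few compounds are considered here, and "the series" means these few. Any claim that something is new, unique, unknown or untested is made for them only; others in the source may bear on it.

Of the compounds shown here, three sharing one core have been measured in an assay on HEK293 cells for agonist activity at transient receptor potential cation channel subfamily M member 8 (Homo sapiens), read by fluorescence and calcium flux, with a stated time of 15 min; a higher number here means that more compound is needed for the effect, a lower number that less compound is needed. Compound 1 `Cc1ccc(OCC(=O)N(Cc2cccs2)c2ncccn2)cc1` gives 3700 nM. Compound 2 `C=CCN(Cc1cccs1)C(=O)COc1ccc(C)cc1` gives 20 nM, and compound 3 `Cc1ccc(OCC(=O)N(Cc2cccs2)C2CC2)cc1` gives 8 nM. Compound 3 stands lowest of the three: the step of a 460-fold lower number from compound 1 to compound 3 (2.67 log units; beyond the scatter) is large, and the step of a 2.5-fold lower number from compound 2 to compound 3 (0.40 log units; beyond the scatter) is modest yet beyond the scatter, so compound 3 is the most potent of the three in this assay.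

Compound 4 `Cc1ccc(OCC(=O)N(Cc2cccs2)c2ccccn2)cc1` differs from compound 3 in one place: pyridin-2-yl in place of cyclopropyl on an amide-type nitrogen. The measured steps that bear on this are the two that exchanged an aromatic group on the amide-type nitrogen for a small non-aromatic one, a 460-fold lower number from compound 1 to compound 3 (2.67 log units; beyond the scatter) and a 190-fold lower number from compound 1 to compound 2 (2.27 log units; beyond the scatter), both large. Compound 4 runs in the opposite direction, placing a six-membered aromatic ring where compound 3 carries cyclopropyl. Pyridin-2-yl is not pyrimidin-2-yl, so the exact size is uncertain, but a large rise in the number is expected for compound 4 in this assay, estimated as a 190-fold higher number from compound 3 to compound 4 (2.27 log units; beyond the scatter). Compound 4 is therefore expected to give about 1500 nM, within a range from 300 nM to 8000 nM.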

Compound 4, half-maximal effective concentration: 200 nM
Compound 4: the middle estimate sits 7.5-fold (0.88 log units) above what was measured, outside the stated range (below it).
By their numbers in this assay, from the lowest: compound 3; then compound 2; then compound 4; then compound 1.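

In this assay, the step of a 19-fold lower number from compound 1 to compound 4 (1.27 log units; beyond the scatter) shows that exchanging pyrimidin-2-yl for pyridin-2-yl, one aromatic ring for another, has a large effect on its own, so the presence of an aromatic ring on the amide-type nitrogen does not alone fix the number. The non-aromatic groups still give the lower numbers, with a 25-fold higher number from compound 3 to compound 4 (1.40 log units; beyond the scatter) large and a 10-fold higher number from compound 2 to compound 4 (1.00 log units; beyond the scatter) modest, and none of the four compounds goes against this order of allyl and cyclopropyl below both aromatic groups. No measurement at hand explains why the two aromatic groups differ or why both stand above the non-aromatic ones.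

The compounds shown leave open where phenyl would fall on this nitrogen, and so whether the rise seen with the aromatic groups depends on the ring nitrogen atoms they carry. They also leave open how a longer chain such as n-butyl, or a chain ending in an amine, would compare with allyl and cyclopropyl at this place.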